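This account rests on a few compounds, and the source may have more. Where it says the series, first, only, none or still open, it means among the compounds named here.

Measured so far in a functional assay on ECa-109 cells for inhibition, with ECa-109 cell line (Homo sapiens) as the target, read by sulforhodamine B assay; on this read-out higher numbers stand for weaker inhibition and lower numbers for stronger inhibition:
compound 1 `O=C1C(Nc2ccccc2F)=CC(=O)c2c1nc1n2[C@H]2OC[C@@H](O)[C@H]2OC1` — 2660 nM
compound 2 `CCc1ccc(NC2=CC(=O)c3nc4n(c3C2=O)[C@H]2OC[C@@H](O)[C@H]2OC4)cc1` — 3080 nM
compound 3 `O=C1C=C(Nc2ccc(Br)cc2)C(=O)c2c1nc1n2[C@H]2OC[C@@H](O)[C@H]2OC1` — 2850 nM

Compound 3 stands second highest of the three numbers, but its gaps to compound 1 and to compound 2 are both within the scatter, so the three are not separable on these data. Compound 4 `O=C1C=C(Nc2ccc(I)cc2)C(=O)c2c1nc1n2[C@H]2OC[C@@H](O)[C@H]2OC1` differs from compound 3 in one place: iodo in place of bromo on an aromatic carbon. Going by the values given here, no measured step exchanges one halogen for another; the only single-point step, a 1.1-fold lower number from compound 2 to compound 3 (0.03 log units; within the scatter), lies within the scatter, and compound 1 with its own halogen sits within the scatter of compound 3 as well. No step beyond the scatter is therefore expected in this assay. Compound 4 is estimated at 2800 nM, with a range of 1400 nM to 5600 nM. The expected step is a 1.0-fold lower number from compound 3 to compound 4 (0.01 log units; within the scatter).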

Compound 4, half-maximal inhibitory concentration: 2300 nM
Compound 4: middle estimate off by 1.2-fold (0.09 log units), on the high side; the measured number falls inside the stated range.
By their numbers in this assay, from the lowest: compounds 4, 1, 3 and 2 (each within the scatter of the next).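

In this assay, going by these compounds alone, this is the first exchange of one halogen for another at this position, and iodo in place of bromo gives a 1.2-fold lower number from compound 3 to compound 4 (0.09 log units; within the scatter), while iodo in place of ethyl gives a 1.3-fold lower number from compound 2 to compound 4 (0.13 log units; within the scatter). On the aromatic carbon para to a large group, ethyl, bromo and iodo therefore remain unseparated, whether the incoming group replaces a halogen or an alkyl chain. No evidence on hand bears on a cause for these steps.

On these data alone, whether an amine or a carboxylic acid at this carbon would give a step beyond the scatter remains open. So does whether any group here separates from these three.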